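Swapping the Brominated Phenyl Group of Compound 3

The source may report more compounds than this note shows. Statements on the series, on what has been measured and on what is new or still open speak of the compounds shown alone.

Of the compounds shown here, three sharing one core have been measured in a functional assay on PC-3 cells (Homo sapiens) for inhibition, read by MTT assay, with a stated time of 48 h, tested at 10 uM; a higher number here means more inhibition of growth at the concentration tested, a lower number less inhibition of growth. Compound 1 `Cc1oc2c([C@H]3CCN(C)C[C@H]3O)c(O)cc(O)c2c(=O)c1C(O)c1ccc([N+](=O)[O-])cc1` gives 24%, compound 2 `Cc1oc2c([C@H]3CCN(C)C[C@H]3O)c(O)cc(O)c2c(=O)c1C(O)c1ccc(Cl)cc1` gives 41%, and compound 3 `Cc1oc2c([C@H]3CCN(C)C[C@H]3O)c(O)cc(O)c2c(=O)c1C(O)c1ccccc1Br` gives 45%. Compound 3 therefore stands level with compound 2 within the scatter and clear of compound 1.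

Compound 4 `Cc1oc2c([C@H]3CCN(C)C[C@H]3O)c(O)cc(O)c2c(=O)c1C(O)c1ccc(F)c(Br)c1` carries 3-bromo-4-fluorophenyl in place of 2-bromophenyl on a saturated chain carbon bound to an aromatic carbon and an oxygen on a saturated carbon. Going by the values given here, the closest precedent is a number 4 percentage points higher from compound 2 to compound 3 (within the scatter), an exchange between two halogen-bearing phenyl groups. The modest steps, a number 17 percentage points higher from compound 1 to compound 2 (beyond the scatter) and a number 21 percentage points higher from compound 1 to compound 3 (beyond the scatter), both start from the 4-nitrophenyl compound, and compound 4 carries no nitro group. Among the compounds with values here, no measured compound carries fluorine, so this part of the change remains untested.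

No shift beyond the scatter is expected in this assay, and the estimated change is a number 2 percentage points lower from compound 3 to compound 4 (within the scatter). For compound 4 the estimated value is 43%, with an expected range from 28% to 58%.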

Compound 4, percent growth inhibition at one concentration: 72%
Compound 4: the middle estimate sits 29 percentage points below what was measured, outside the stated range (above it).
By their numbers in this assay, from the lowest: compound 1; then compounds 2 and 3 (each within the scatter of the next); then compound 4.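

In this assay, exchanging 2-bromophenyl for 3-bromo-4-fluorophenyl on the saturated chain carbon gives a number 27 percentage points higher from compound 3 to compound 4 (beyond the scatter), and the same group gives a number 31 percentage points higher from compound 2 to compound 4 (beyond the scatter) against 4-chlorophenyl and a number 48 percentage points higher from compound 1 to compound 4 (beyond the scatter) against 4-nitrophenyl. The within-scatter step between compound 2 and compound 3 had made halogen-bearing phenyl groups look interchangeable here, but compound 4 shows that they are not, and it stands clear of the other three compounds. Nothing available explains why this group stands apart from the others.

The compounds shown do not separate the contribution of the fluorine from that of the bromine, since none has a phenyl group carrying fluorine alone or 3-bromophenyl. Going by these compounds, whether a pyridine ring or an amine on the phenyl group would be tolerated at this position also remains open.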